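Quinolin-2-yl in place of phenyl on the amide carbonyl

The source may hold more compounds than are shown below. What is called first, only, known or untested is meant among the compounds shown, and "the series" means these compounds.

Measured compounds:
compound 1 `CCN1CCN(c2cc(C)c3cc(NC(=O)c4ccccc4)ccc3n2)CC1` — 14200 nM
compound 2 `Cc1cc(N2CCCC2)nc2ccc(NC(=O)c3ccc(Cl)c(Cl)c3)cc12` — 26300 nM

The study measures antiproliferative activity in a functional assay on MCF7 cells (Homo sapiens) for antiproliferative activity, read by MTT assay, with a stated time of 72 h; a lower number here means a stronger inhibitor, a higher number a weaker inhibitor. In this assay compound 1 gives 14200 nM, and compound 2 gives 26300 nM. Compound 1 holds the lowest of the two numbers, but its gap to compound 2 lies within the scatter, so no order between them can be claimed.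

The compound still to be measured is compound 3 `CCN1CCN(c2cc(C)c3cc(NC(=O)c4ccc5ccccc5n4)ccc3n2)CC1`. Compared with compound 1 it carries quinolin-2-yl in place of phenyl on a carbonyl carbon. For the measured compounds named here, no step between two measured compounds shows what such a change does here, so the expectation rests on compound 1 alone, anchored by 14200 nM. A modest move toward a lower number is expected, with a 1.8-fold lower number from compound 1 to compound 3 (0.25 log units; within the scatter) as the estimated step, and it may well stay within the scatter. Compound 3 is therefore estimated to give 8000 nM, within a range from 2500 nM to 30000 nM.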

Compound 3, half-maximal inhibitory concentration: 7060 nM
Compound 3: middle estimate off by 1.1-fold (0.05 log units), on the high side; measured number inside the range.
By their numbers in this assay, from the lowest: compounds 3, 1 and 2 (each within the scatter of the next, the first and the last beyond it).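

On the carbonyl carbon whose other neighbour is the amide-type nitrogen, quinolin-2-yl can stand in place of phenyl without a change that can be told from scatter: in this assay, the step is a 2.0-fold lower number from compound 1 to compound 3 (0.30 log units; within the scatter). For the compounds shown here, this is the first comparison between compounds that differ in one place, and it shows that adding a second aromatic ring and a hydrogen-bond acceptor to this group leaves the number within the scatter of compound 1. No measurement shown here bears on the reason for this result.

The compounds shown leave open whether any group at this place can move the number beyond the scatter. A pyridin-2-yl group, or a quinolin-2-yl group carrying an amine or a carboxylic acid, would test this further.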